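Benzyl for methyl on the piperidine of a urea agonist

A few compounds are considered here, and "the series" means these few. Any claim that something is new, unique, unknown or untested is made for them only; others in the source may bear on it.

Measured compounds:
- compound 1, `CC1CCN(c2nc(C(F)(F)F)ccc2CNC(=O)Nc2cccc3c(=O)[nH]ccc23)CC1`: 9.59 nM
- compound 2, `CC1CCN(c2nc(C(F)(F)F)ccc2CNC(=O)Nc2cccc3ccc(=O)[nH]c23)CC1`: "not active" (no number reported)

In an assay on CHO cells for agonist activity at transient receptor potential cation channel subfamily V member 1 (Homo sapiens) (on this read-out higher numbers stand for an effect only at larger amounts of compound and lower numbers for an effect already at smaller amounts), compound 1 gives 9.59 nM. In this assay compound 2 is reported as "not active" (no number reported), so compound 1 is the only compound with a number, and compound 2 stands apart as an entry without one; the two share the pyridine-piperidine urea part and differ in how the bicyclic end is built, but no single-point step between them is shown.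

Compound 3, `O=C(NCc1ccc(C(F)(F)F)nc1N1CCC(Cc2ccccc2)CC1)Nc1cccc2c(=O)[nH]ccc12`, has not yet been measured. It differs from compound 1 by phenyl in place of hydrogen on a saturated chain carbon bound to a saturated ring carbon. The change keeps the urea, the trifluoromethyl pyridine and the bicyclic end of compound 1 unchanged and only enlarges the substituent on the saturated ring.

Going by the values given here, with no comparable step among the measured compounds, the size of the change is open. The author expects the step from compound 1 to compound 3 to be modest, a 2.6-fold higher number from compound 1 to compound 3 (0.42 log units; beyond the scatter), leaning toward a weaker effect but possibly within the scatter. For compound 3 the estimate in this assay is 25 nM, with a range from 5 nM to 120 nM.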

Compound 3, half-maximal effective concentration: 5.81 nM
The estimate for compound 3 lay 4.3-fold (0.63 log units) above the measured number, within the range that was stated.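

Going by these compounds alone, until now compound 1 was the only compound with a number, so nothing showed how much room there was on the saturated ring of this urea agonist. In this assay, methyl to benzyl, which is phenyl in place of hydrogen on a saturated chain carbon bound to a saturated ring carbon, gives a 1.7-fold lower number from compound 1 to compound 3 (0.22 log units; within the scatter) and leaves the two compounds indistinguishable, so this position accepts a much larger carbon-only aromatic group with no measurable loss of the effect in this one assay. Nothing shown explains why the read-out holds through so large a change. This single step gives the only view of this position and shows no limit to the size of group that it accepts.

The compounds shown leave open whether the benzyl ring itself can carry substituents, such as an amine or a carboxylic acid, and whether a longer chain, such as phenethyl, would keep the effect. They also leave open whether the benzyl group would behave the same way on the bicyclic end of compound 2, which has no number.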